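Swapping the ethynyl group for furan-3-yl

The source may hold more compounds than are shown below. What is called first, only, known or untested is meant among the compounds shown, and "the series" means these compounds.

Measured in a functional assay on HL-60 cells (Homo sapiens) for antiproliferative activity, with a stated time of 72 h; a higher number here means a weaker inhibitor, a lower number a stronger inhibitor:
- Compound 1 `CCCC#Cc1cc([C@@H]2O[C@H](CO)[C@@H](O)[C@H]2O)n2ncnc(N)c12`: 200 nM
- Compound 2 `Nc1ncnn2c([C@@H]3O[C@H](CO)[C@@H](O)[C@H]3O)cc(C#CC3CC3)c12`: 40 nM
- Compound 3 `Nc1ncnn2c([C@@H]3O[C@H](CO)[C@@H](O)[C@H]3O)cc(C#Cc3ccc(F)cc3)c12`: > 100000 nM (a limit)

Compound 3 stands at > 100000 nM, which is a limit and not a number. The large steps of an at least 500-fold higher number from compound 1 to compound 3 (2.69 log units; beyond the scatter) and an at least 2500-fold higher number from compound 2 to compound 3 (3.39 log units; beyond the scatter) lead to it, while a 5.0-fold lower number from compound 1 to compound 2 (0.70 log units; beyond the scatter) is modest. In compound 4 `Nc1ncnn2c([C@@H]3O[C@H](CO)[C@@H](O)[C@H]3O)cc(-c3ccoc3)c12`, furan-3-yl takes the place of 2-(4-fluorophenyl)ethynyl on an aromatic carbon: furan-3-yl in place of 2-(4-fluorophenyl)ethynyl on an aromatic carbon. Within the data shown here, no measured step tests a furan-3-yl, but all three show what changing the group on the shared core does at a neighbouring triple-bonded carbon. Compound 1 at 200 nM and compound 2 at 40 nM show that this core can give a measurable number, so a large step to a lower number is expected. The expected step is an at least 200-fold lower number from compound 3 to compound 4 (2.30 log units; beyond the scatter). For compound 4 the estimated value is 500 nM, with an expected range of 40 nM to 20000 nM.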

Compound 4, half-maximal inhibitory concentration: 500 nM
For compound 4 middle estimate and measured number coincide at the digits printed; the range from low to high includes it.
By their numbers in this assay, from the lowest: compound 2; then compound 1; then compound 4. At a limit, above all of these: compound 3.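

Replacing the 2-(4-fluorophenyl)ethynyl group with furan-3-yl gives an at least 200-fold lower number from compound 3 to compound 4 (2.30 log units; beyond the scatter) in this assay, so a ring bonded directly to this aromatic carbon, with no triple bond, can give a measurable number. Compound 3 remains a limit, so that step is only a bound: the limit of > 100000 nM in this assay, at which 1 of the 4 values shown sits. Furan-3-yl does not match the two smaller alkynes, with a 13-fold higher number from compound 2 to compound 4 (1.10 log units; beyond the scatter) and the more moderate a 2.5-fold higher number from compound 1 to compound 4 (0.40 log units; beyond the scatter) in the same assay.

Going by these compounds, whether a thiophen-3-yl or a phenyl group, or an amine, on this carbon would give a number like that of compound 4 stays open.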